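Swapping 3-cyanophenyl for 4-methylphenyl on the amide carbonyl

The compounds below may be only part of what the source reports. "The series", "measured", "known", "first", "only" and "open" are said of these compounds alone.

Three amides on a shared core have been measured in a functional assay on MCF7 cells (Homo sapiens) for inhibition, read by MTT assay; a higher number here means a weaker inhibitor of growth, a lower number a stronger inhibitor of growth. Compound 1 `COc1cc2oc(-c3cccc(NC(=O)c4ccc(Br)cc4)c3)cc(=O)c2c(OC)c1OC` gives 9650 nM, compound 2 `COc1cc2oc(-c3cccc(NC(=O)c4ccc(C#N)cc4)c3)cc(=O)c2c(OC)c1OC` gives 12700 nM and compound 3 `COc1cc2oc(-c3cccc(NC(=O)c4cccc(C#N)c4)c3)cc(=O)c2c(OC)c1OC` gives 41700 nM. Compound 3 thus has the highest number of the three and is the weakest inhibitor of growth in this set.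

The next compound is compound 4 `COc1cc2oc(-c3cccc(NC(=O)c4ccc(C)cc4)c3)cc(=O)c2c(OC)c1OC`, which carries 4-methylphenyl in place of 3-cyanophenyl on a carbonyl carbon. For the measured compounds named here, no measured compound carries a methyl group, so the evidence is indirect. Moving the nitrile gave a 3.3-fold higher number from compound 2 to compound 3 (0.52 log units; beyond the scatter), and the change from the bromo compound gave a 4.3-fold higher number from compound 1 to compound 3 (0.64 log units; beyond the scatter). Exchanging bromo for cyano, by contrast, gave only a 1.3-fold higher number from compound 1 to compound 2 (0.12 log units; within the scatter). Compound 4 shares the 4-substituted pattern of compound 1 and compound 2, so a modest step toward a lower number is expected in this assay. The expected change is a 3.2-fold lower number from compound 3 to compound 4 (0.51 log units; beyond the scatter). For compound 4 the estimated value is 13000 nM, within an expected range of 5500 nM to 30000 nM.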

Compound 4, concentration for 50% growth inhibition: 8320 nM
Beside the measured number, compound 4's estimate is 1.6-fold (0.19 log units) above it; the range from low to high includes it.
By their numbers in this assay, from the lowest: compounds 4, 1 and 2 (each within the scatter of the next); then compound 3.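

With compound 4 the number falls again, a 5.0-fold lower number from compound 3 to compound 4 (0.70 log units; beyond the scatter) in this assay, so the high value of compound 3 is not shared by a 4-substituted ring that carries no nitrile and no halogen. Among the 4-substituted amides the methyl group is not told apart from the other two substituents, with a 1.5-fold lower number from compound 2 to compound 4 (0.18 log units; within the scatter) and a 1.2-fold lower number from compound 1 to compound 4 (0.06 log units; within the scatter). Bromo, cyano and now methyl thus all sit within the scatter of one another at this place, which extends what the bromo and cyano pair showed to a third, quite different group, and compound 3 remains the one compound apart.

No data on hand account for these differences. Compound 3 is the only example of its substitution pattern, so the compounds shown leave open whether its number goes with the place of the group or with the nitrile itself, and how a carboxylic acid, an amine or a longer chain would read on this ring.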